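The source may report more compounds than this note shows. Statements on the series, on what has been measured and on what is new or still open speak of the compounds shown alone.

compound 1 `CCc1cccc2c1nc(-c1c(F)cccc1F)n2Cc1c(F)cccc1F`: 26.1 uM
compound 2 `CN(C)C(=O)c1cccc2c1nc(-c1c(F)cccc1F)n2Cc1c(F)cccc1F`: 80.1 uM

Of these two, compound 2 stands highest in a toxicity assay on CCRF-CEM cells (Homo sapiens) for cytotoxicity; a higher number here means that more compound is tolerated, a lower number that less compound is tolerated. Compound 3 `NCc1cccc2c1nc(-c1c(F)cccc1F)n2Cc1c(F)cccc1F` is reached from compound 2 by placing aminomethyl in place of dimethylcarbamoyl on an aromatic carbon. For the measured compounds named here, the only measured step at this place is a 3.1-fold higher number from compound 1 to compound 2 (0.49 log units; beyond the scatter), and it is a modest one. Going by the values given here, with the dimethylcarbamoyl gone, a move of similar size back towards a lower number is expected in this assay, though no aminomethyl compound has been measured yet. The estimated change is a 2.9-fold lower number from compound 2 to compound 3 (0.46 log units; beyond the scatter). For compound 3 the expected value is 28 uM, with an estimated range of 10 uM to 70 uM.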

Compound 3, half-maximal toxic concentration: 49.3 uM
Beside the measured number, compound 3's estimate is 1.8-fold (0.25 log units) below it; low and high end bracket the measured number.
By their numbers in this assay, from the lowest: compounds 1, 3 and 2 (each within the scatter of the next, the first and the last beyond it).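

In this assay aminomethyl gives a 1.6-fold lower number from compound 2 to compound 3 (0.21 log units; within the scatter) and, seen from the ethyl compound, a 1.9-fold higher number from compound 1 to compound 3 (0.28 log units; within the scatter) so at this aromatic carbon it cannot be told apart from either neighbour in the series. That holds even though ethyl and dimethylcarbamoyl themselves are separated by a 3.1-fold higher number from compound 1 to compound 2 (0.49 log units; beyond the scatter) and the aminomethyl compound therefore adds no third distinct level at this place. Nothing available explains these numbers.

On these data alone, whether a carboxylic acid or a longer chain on this aromatic carbon would fall outside the span of compound 1 and compound 2 stays open. A tertiary amine such as dimethylaminomethyl would show whether the amine hydrogens matter here.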